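This account rests on a few compounds, and the source may have more. Where it says the series, first, only, none or still open, it means among the compounds named here.

Measured so far: compound 1 `CCc1ccc(NS(=O)(=O)c2ccc(N3CCNC3=O)cc2)cc1` gives 480 nM in a functional assay on M21 cells (Homo sapiens) for antiproliferative activity, read by sulforhodamine B assay, with a stated time of 48 h; on this read-out higher numbers stand for weaker inhibition and lower numbers for stronger inhibition; compound 2 `Cc1cccc(NS(=O)(=O)c2ccc(N3CCNC3=O)cc2)c1C` gives 110 nM; compound 3 `Cc1ccc(NS(=O)(=O)c2ccc(N3CCNC3=O)cc2)cc1C` gives 94 nM. Compound 1 has the highest number of the three: a 4.4-fold lower number from compound 1 to compound 2 (0.64 log units; beyond the scatter) and a 5.1-fold lower number from compound 1 to compound 3 (0.71 log units; beyond the scatter), both modest. Compound 4 `CCCCCCCc1ccc(NS(=O)(=O)c2ccc(N3CCNC3=O)cc2)cc1` keeps the core of compound 1 and differs only in one place: pentyl in place of hydrogen on a saturated chain carbon, two bonds along the chain from an aromatic carbon. Neither measured step tests a longer chain; they only show that replacing the 4-ethylphenyl can lower the number modestly, and compound 2 and compound 3 sit within the scatter of each other, so the direction for compound 4 is open. A step of a 1.5-fold higher number from compound 1 to compound 4 (0.16 log units; within the scatter) is expected, with wide uncertainty. Compound 4 is estimated at 700 nM, between 150 nM and 3500 nM.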

Compound 4, half-maximal inhibitory concentration: > 1000 nM
Compound 4: only a limit was reported; the forecaster's own chance of this, stated with the estimate: 10%; middle value at least 1.4-fold (0.15 log units) away from the limit.
By their numbers in this assay, from the lowest: compounds 3 and 2 (each within the scatter of the next); then compound 1. At a limit, above all of these: compound 4.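

In this assay, pentyl in place of hydrogen on this saturated chain carbon gives an at least 2.0-fold higher number from compound 1 to compound 4 (0.31 log units; beyond the scatter). Among the steps shown from compound 1, this is the only one that raises the number, while the two dimethylphenyl changes lower it. Compound 4 is reported only as a limit, so this step gives a minimum size and no exact value: the limit of > 1000 nM in this assay, at which 1 of the 4 values shown sits.

On these data alone, whether a shorter propyl or butyl chain here would stay close to compound 1 remains open. So does whether a chain carrying an amine or a carboxylic acid would behave like the pentyl-extended one.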